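The compounds below may be only part of what the source reports. "The series", "measured", "known", "first", "only" and "open" are said of these compounds alone.

Measured so far:

- compound 1, `N#Cc1ccc(-c2nc(C(c3ccc(F)cc3)c3ccc(F)cc3)sc2CC(=O)O)cc1`, in an in vitro assay on HEK385-7 cells for displacement of a labelled ligand from prostaglandin D2 receptor 2 (Homo sapiens) (a higher number here means a weaker inhibitor, a lower number a stronger inhibitor), gives 150 nM
- compound 2, `O=C(O)Cc1sc(C(c2ccc(F)cc2)c2ccc(F)cc2)nc1-c1ccco1`, in this assay gives 18 nM
- compound 3, `O=C(O)Cc1sc(C(c2ccc(F)cc2)c2ccc(F)cc2)nc1-c1cc(F)nc(F)c1`, in this assay gives 5.4 nM

Compound 3 has the lowest number of the three. The step of a 28-fold lower number from compound 1 to compound 3 (1.44 log units; beyond the scatter) is large, and the step of a 3.3-fold lower number from compound 2 to compound 3 (0.52 log units; beyond the scatter) is modest; both lie beyond the scatter, so compound 3 is the strongest of the three measured.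

Compound 4, `O=C(O)Cc1sc(C(c2ccc(F)cc2)c2ccc(F)cc2)nc1-c1ccnc(O)c1`, differs from compound 3 in one place: 2-hydroxypyridin-4-yl in place of 2,6-difluoropyridin-4-yl on an aromatic carbon. All three measured steps swap the whole ring that sits on the shared core, and each swap moved the number by a clear amount, so this position is sensitive. Among the compounds with values here, no measured compound carries a hydroxyl on this ring, and none shows what removing the two fluorines alone does, so the direction rests on the one observation that compound 3, the fluorinated pyridine, gives the lowest number. A modest rise is expected, a 3.7-fold higher number from compound 3 to compound 4 (0.57 log units; beyond the scatter). Compound 4 is therefore estimated at 20 nM, within 6 nM to 70 nM.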

Compound 4, half-maximal inhibitory concentration: 68 nM
The estimate for compound 4 lay 3.4-fold (0.53 log units) below the measured number, within the range that was stated.
By their numbers in this assay, from the lowest: compound 3; then compound 2; then compound 4; then compound 1.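

Two rings of the same kind, each a six-membered aromatic ring with one hetero atom, are told apart sharply at this position (a 13-fold higher number from compound 3 to compound 4 (1.10 log units; beyond the scatter)), so the substituents on the ring matter here and not only the type of ring. The 2-hydroxypyridin-4-yl group falls in the middle of the series, worse than furan-2-yl (a 3.8-fold higher number from compound 2 to compound 4 (0.58 log units; beyond the scatter)) but better than 4-cyanophenyl (a 2.2-fold lower number from compound 1 to compound 4 (0.34 log units; beyond the scatter)), so a ring bearing a hydroxyl is still better here than the 4-cyanophenyl ring. Nothing available explains why the number rose.

Going by these compounds, this swap removes two fluorines and adds a hydroxyl in a single step, so the share of each in the rise stays unknown. A plain pyridin-4-yl with neither group, or a methoxy group in place of the hydroxyl, would help to separate the two.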